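Dichlorophenyl ether on a shared spirocyclic triazine core

A few compounds are considered here, and "the series" means these few. Any claim that something is new, unique, unknown or untested is made for them only; others in the source may bear on it.

Measured compounds:
compound 1, `NC1=NC2(CCOCC2)N(OCCCOc2cccc(Cl)c2)C(N)=N1`, 520 nM
compound 2, `NC1=NC2(CCOCC2)N(OCCCOc2cc(Cl)c(Cl)cc2Cl)C(N)=N1`, 2360 nM
compound 3, `Cc1ccc(OCCCON2C(N)=NC(N)=NC23CCOCC3)cc1`, 2580 nM

In a functional assay on HL-60 cells (Homo sapiens) for antiproliferative activity, read by MTT assay, with a stated time of 72 h (a higher number here means a weaker inhibitor, a lower number a stronger inhibitor), compound 3 gives the highest of the three numbers. Its nearest neighbour is compound 2, and the step of a 1.1-fold higher number from compound 2 to compound 3 (0.04 log units; within the scatter) stays within the scatter, so the two cannot be told apart. The step of a 5.0-fold higher number from compound 1 to compound 3 (0.70 log units; beyond the scatter) is beyond the scatter, and compound 1 stands well clear of both.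

Compound 4, `NC1=NC2(CCOCC2)N(OCCCOc2cccc(Cl)c2Cl)C(N)=N1`, is the next compound. It differs from compound 3 in one place: 2,3-dichlorophenyl in place of 4-methylphenyl on an oxygen on a saturated carbon.

Among the measured compounds shown here, two measured steps bear on this change. The step of a 5.0-fold higher number from compound 1 to compound 3 (0.70 log units; beyond the scatter) shows that the 4-methylphenyl stands clearly behind the 3-chlorophenyl. The step of a 4.5-fold higher number from compound 1 to compound 2 (0.66 log units; beyond the scatter) shows that adding two further chlorines to a chlorophenyl gave a modestly higher number. Since the 2,3-dichlorophenyl carries the chlorine of compound 1 plus one more, a lower number than compound 3 is expected, though not fully back to compound 1. Compound 4 is therefore estimated at 1000 nM, within 350 nM to 3000 nM, which would mean an expected step of a 2.6-fold lower number from compound 3 to compound 4 (0.41 log units; beyond the scatter).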

Compound 4, half-maximal inhibitory concentration: 440 nM
Compound 4: the middle estimate sits 2.3-fold (0.36 log units) above what was measured; the range from low to high includes it.
By their numbers in this assay, from the lowest: compounds 4 and 1 (each within the scatter of the next); then compounds 2 and 3 (each within the scatter of the next).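

In this assay, chloro in place of hydrogen on an aromatic carbon gives a 1.2-fold lower number from compound 1 to compound 4 (0.07 log units; within the scatter), so the added chlorine leaves no readable change and compound 1 and compound 4 cannot be told apart. The other two steps, a 5.9-fold lower number from compound 3 to compound 4 (0.77 log units; beyond the scatter) and a 5.4-fold lower number from compound 2 to compound 4 (0.73 log units; beyond the scatter), are beyond the scatter, and they show that the number of chlorines alone does not set the result: the 2,3-dichlorophenyl of compound 4 stands clear of the 2,4,5-trichlorophenyl of compound 2, although both carry more than one chlorine. No measurement at hand accounts for these differences.

The compounds shown leave open whether a bromo or a trifluoromethyl could take the place of chloro on this phenyl ring without a readable change. They also leave open how a longer chain on the oxygen would compare.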